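The source may report more compounds than this note shows. Statements on the series, on what has been measured and on what is new or still open speak of the compounds shown alone.

Two compounds share one core and differ only in the group on the nitrogen attached to the aromatic ring. Compound 1, `CN(C)S(=O)(=O)Nc1cccc2c1CCCC2c1c[nH]cn1`, gives 1580 nM in an assay on isolated protein for binding affinity to Alpha-1D adrenergic receptor (Rattus norvegicus), read by radioligand binding; a higher number here means a weaker inhibitor, a lower number a stronger inhibitor. Compound 2, `O=C(Nc1cccc2c1CCCC2c1c[nH]cn1)C(F)(F)F`, gives 3310 nM, which is the higher of the two numbers shown; the single measured step, a 2.1-fold higher number from compound 1 to compound 2 (0.32 log units; beyond the scatter), is a modest one. Compound 3, `Oc1cccc2c1CCCC2c1c[nH]cn1`, has not been measured. Its change from compound 2 is hydroxy in place of ((trifluoromethyl)carbonyl)amino on an aromatic carbon. For the measured compounds named here, no measured step swaps the whole acylamino group for a hydroxy, so the one step known, from compound 1 to compound 2, bears on it only indirectly: it shows that changing this group shifts the number modestly. A step of similar modest size in this assay is therefore expected, with the direction uncertain but leaning toward a lower number, so that compound 3 is estimated at 1500 nM, within 300 nM to 8000 nM, a step of a 2.2-fold lower number from compound 2 to compound 3 (0.34 log units; beyond the scatter).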

Compound 3, inhibition constant: 30.9 nM
Estimate against measurement, compound 3: 49-fold (1.69 log units) above; measured number outside the range, below it.
By their numbers in this assay, from the lowest: compound 3; then compound 1; then compound 2.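

In this assay, this aromatic carbon proves far more sensitive to its substituent than the earlier pair suggested: hydroxy in place of ((trifluoromethyl)carbonyl)amino gives a 110-fold lower number from compound 2 to compound 3 (2.03 log units; beyond the scatter), and hydroxy in place of (dimethylsulfamoyl)amino gives a 51-fold lower number from compound 1 to compound 3 (1.71 log units; beyond the scatter). Both steps are large, whereas the exchange between the two nitrogen-linked groups was only modest, so the biggest change among these compounds comes from replacing either of those groups with hydroxy. No measurement available here explains this gain in binding.

These compounds cannot separate a benefit of hydroxy itself from a benefit of losing the larger groups; a methoxy group, a plain amine or a bare hydrogen at this place would help distinguish the two. As far as these compounds go, whether hydroxy would give a similar gain with a different group elsewhere on the shared core also remains open.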